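This account rests on a few compounds, and the source may have more. Where it says the series, first, only, none or still open, it means among the compounds named here.

Compound 1 `CCCCCCCCNC1=CC(=O)C=C(C[C@]2(C)[C@@H](C)CC[C@]3(C)C(C)=CCC[C@@H]23)C1=O` gives 38000 nM as a measured number
Compound 2 `CCCCNC1=CC(=O)C=C(C(C)(C)C)C1=O` gives 14000 nM as a measured number
Compound 3 `CCCCCCCCNC1=CC(=O)C(C[C@]2(C)[C@@H](C)CC[C@]3(C)C(C)=CCC[C@@H]23)=CC1=O` gives > 100000 nM as a limit of the assay, not a number

In a functional assay on NCI-H460 cells (Homo sapiens) for cytotoxicity, read by MTT assay, with a stated time of 72 h (a higher number here means a weaker inhibitor, a lower number a stronger inhibitor), compound 1 at 38000 nM is the higher of the two actual numbers in this small set, and compound 2 lies lower by a gap beyond the usual scatter. Compound 3 has only a limit, > 100000 nM and no number.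

Compound 4 `CCCCNC1=CC(=O)C=C(C[C@]2(C)[C@@H](C)CC[C@]3(C)C(C)=CCC[C@@H]23)C1=O` has not yet been measured. It departs from compound 1 by the change hydrogen in place of butyl on a saturated chain carbon, four bonds along the chain from an amine nitrogen and that means hydrogen in place of butyl on a saturated chain carbon, four bonds along the chain from an amine nitrogen. Among the measured compounds shown here, no measured pair shows this change on its own, so any forecast is loose. A modest move in this assay toward a lower number is expected because compound 2 at 14000 nM shows that lower numbers occur in this set. The estimated change is a 1.9-fold lower number from compound 1 to compound 4 (0.28 log units; within the scatter) and it may not clear the scatter by much. For compound 4 the estimated value is 20000 nM with an expected range from 6000 nM to 70000 nM as the likely span.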

Compound 4, half-maximal inhibitory concentration: 16000 nM
Compound 4: middle estimate off by 1.3-fold (0.10 log units), on the high side; low and high end bracket the measured number.
By their numbers in this assay, from the lowest: compounds 2 and 4 (each within the scatter of the next); then compound 1. At a limit, above all of these: compound 3.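

In this assay, among the compounds shown here, putting hydrogen in place of butyl on a saturated chain carbon, four bonds along the chain from an amine nitrogen, gives a 2.4-fold lower number from compound 1 to compound 4 (0.38 log units; beyond the scatter) and is the first one-place change in this set. The position therefore responds to the chain, and the shorter chain does not cost activity here. Compound 4 at 16000 nM and compound 2 at 14000 nM lie within the scatter of each other, so with the same chain on the amine nitrogen, their different groups on the shared core give values that cannot be ranked.

The data shown give no reason for this step. As far as these compounds go, one step sets no trend, so it remains open how a hexyl chain, or a chain ending in an amine or a carboxylic acid, would compare.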